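Swapping trifluoromethyl for dimethylamino on a urea-linked ring

The source may report more compounds than this note shows. Statements on the series, on what has been measured and on what is new or still open speak of the compounds shown alone.

Of the compounds shown here, two built on the same core have been tested in an ADME assay on Raji cells (Homo sapiens) for cytotoxicity, with a stated time of 72 h; on this read-out higher numbers stand for an effect only at larger amounts of compound and lower numbers for an effect already at smaller amounts. Compound 1 `Cc1cc(NC(=O)Nc2ccc(C(=O)O)cc2)c2ccccc2n1` carries a carboxylic acid on the ring joined to the urea. In this assay compound 1 reaches only a limit of the assay, > 25000 nM, so no number is known for it. Compound 2 `Cc1cc(NC(=O)Nc2cccc(C(F)(F)F)c2)c2ccccc2n1` instead carries trifluoromethyl on that ring. In this assay compound 2 gives 10000 nM. For the measured compounds named here, compound 2 therefore stands as the only compound with a number in this assay; the other value is a limit, as noted in the limit of > 25000 nM in this assay, at which 1 of the 2 values shown sits.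

Compound 3 `Cc1cc(NC(=O)Nc2cccc(N(C)C)c2)c2ccccc2n1` has not yet been measured. It differs from compound 2 in one place: dimethylamino in place of trifluoromethyl on an aromatic carbon. Going by the values given here, no measured pair differing in one place exists here, so the size and direction of this step cannot be read from the data. The step from compound 2 to compound 3 in this assay is expected to be small, a 1.5-fold higher number from compound 2 to compound 3 (0.18 log units; within the scatter), possibly not beyond the usual scatter. For compound 3 in this assay the estimate is 15000 nM, with a range from 5000 nM to 40000 nM.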

Compound 3, half-maximal effective concentration: > 25000 nM
Compound 3 gave a limit, no number; the forecaster's own chance of this, stated with the estimate: 40%; middle value at least 1.6-fold (0.22 log units) away from the limit.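

In this assay, for the compounds shown here, putting dimethylamino in place of trifluoromethyl on this aromatic carbon gives an at least 2.5-fold higher number from compound 2 to compound 3 (0.39 log units; beyond the scatter), the first step in this set that can be read at all. This shows that the position is not indifferent to the group it carries, since the change moves the result by more than repeated measurements would be expected to scatter. The result for compound 3 is a limit of the assay rather than a number, so the step has a known lower bound but no known full size, and compound 2 remains the only compound with a measured value: the limit of > 25000 nM in this assay, at which 2 of the 3 values shown sit.

The compounds shown leave open whether a chlorine atom, a methoxy group or a nitrile on the same aromatic carbon would give a measurable number in this assay or would also reach the limit. Going by these compounds alone, with only two groups compared at this position, they also do not show which feature of the exchanged groups accounts for the step.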